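Pyrimidinyl piperazine variant of a fluorophenyl imide series

The source may report more compounds than this note shows. Statements on the series, on what has been measured and on what is new or still open speak of the compounds shown alone.

Compound 1 `CC1(c2ccccc2)CC(=O)N(CC(=O)N2CCN(c3ccccc3F)CC2)C1=O` in a functional assay on the whole organism (strain CD-1) with Mus musculus as the target, with a stated time of 2 h (on this read-out lower numbers stand for an effect already at smaller amounts and higher numbers for an effect only at larger amounts of compound), gives 300 mg/kg. For the measured compounds named here, compound 2 `CC1(c2ccccc2)CC(=O)N(CC(=O)N2CCN(c3ccc(F)cc3)CC2)C1=O` in this assay is recorded as "not active" (no number reported), so no number stands for compound 2 and no step from it can be sized. Compound 3 `CC1(c2ccccc2)CC(=O)N(CC(=O)N2CCN(c3ncccn3)CC2)C1=O` differs from compound 2 by pyrimidin-2-yl in place of 4-fluorophenyl on an amine nitrogen in a ring. Going by the values given here, with no measured step of this kind, the change from compound 2 is expected to be no more than a shift within the scatter, in no fixed direction, and a further inactive result remains likely. Compound 3 is estimated at 300 mg/kg in this assay, within 100 mg/kg to 1000 mg/kg.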

Compound 3, minimum effective dose: 100 mg/kg
Compound 3: middle estimate off by 3.0-fold (0.48 log units), on the high side, within the range that was stated.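

In this assay, pyrimidin-2-yl in place of 2-fluorophenyl on the amine nitrogen in a ring gives a 3.0-fold lower number from compound 1 to compound 3 (0.48 log units; beyond the scatter) and shows that this place accepts an aromatic ring with hetero atoms while an effect remains. The step from compound 2 to compound 3 cannot be read, as compound 2 carries no number. No measurement at hand accounts for the step. Open, going by these compounds, is whether a pyridine ring or an unsubstituted phenyl ring at this place gives a number like that of compound 3.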